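A 3-fluorophenyl swap on compound 1

The compounds below may be only part of what the source reports. "The series", "measured", "known", "first", "only" and "open" are said of these compounds alone.

Among the compounds with values here, only two compounds have numbers so far in a functional assay on HeLa cells (Homo sapiens) for antiproliferative activity, read by MTT assay, with a stated time of 72 h; a lower number here means a stronger inhibitor, a higher number a weaker inhibitor. Compound 1 (`CCCNC(=O)c1cc(Oc2ccc(NC(=O)c3nn(-c4ccc(C)cc4)c(=O)cc3C)cc2F)ccn1`) gives 14200 nM, the higher of the two numbers and so the weaker inhibitor, while compound 2 (`CCNC(=O)c1cc(Oc2ccc(NC(=O)c3nn(-c4cccc(F)c4)c(=O)cc3C)cc2)ccn1`) gives 6870 nM. That gap lies beyond the usual scatter of repeated measurements.

The next compound, compound 3 (`CCCNC(=O)c1cc(Oc2ccc(NC(=O)c3nn(-c4cccc(F)c4)c(=O)cc3C)cc2F)ccn1`), keeps the core of compound 1 and changes one group: 3-fluorophenyl in place of 4-methylphenyl on an aromatic nitrogen. Within the data shown here, no pair of measured compounds shows this swap on its own, so any forecast is loose. Among the measured compounds shown here, the only hint is that compound 2, which also carries 3-fluorophenyl, reads 6870 nM in this assay, yet it is not a matched partner of compound 1. A small move towards a lower number therefore seems most likely, and it may not clear the scatter. The expected change is a 1.5-fold lower number from compound 1 to compound 3 (0.17 log units; within the scatter), which is only an estimate. For compound 3 the estimated value is 9500 nM, with an expected range from 4000 nM to 20000 nM.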

Compound 3, half-maximal inhibitory concentration: 6660 nM
Compound 3: the middle estimate sits 1.4-fold (0.15 log units) above what was measured; the range from low to high includes it.
By their numbers in this assay, from the lowest: compounds 3 and 2 (each within the scatter of the next); then compound 1.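

In this assay, the swap gives a 2.1-fold lower number from compound 1 to compound 3 (0.33 log units; beyond the scatter). Within the data shown here, this is the first pair that differs in one place only, so it ties a modest change in the number directly to the group on this aromatic nitrogen. The two groups match in heavy atoms, in their single six-membered aromatic ring of carbon only and in having no hydrogen-bond donors or acceptors, so these counts do not separate them, and the step instead tracks a swap of the methyl group for fluorine along with a change in where that substituent sits on the ring. Nothing measured here accounts for the step.

The compounds shown leave open whether the lower number follows the fluorine, the loss of the methyl group or the changed position of the substituent, and an unsubstituted phenyl group or a chlorophenyl group at the same nitrogen would be informative. From the compounds shown here alone, it also remains open whether the same swap would give a similar step with an ethyl amide chain or elsewhere.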